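Removing a Chlorine: What to Expect for Compound 4

The source may hold more compounds than are shown below. What is called first, only, known or untested is meant among the compounds shown, and "the series" means these compounds.

Compound 1 `N=C(N)c1ccc(-c2ccc(-c3cc(Cl)cc(Cl)c3)s2)cc1` — 1750 nM
Compound 2 `N=C(N)c1ccc(-c2ccc(-c3ccc(Cl)cc3)s2)cc1F` — 1150 nM
Compound 3 `COc1cc(OC)cc(-c2ccc(-c3ccc(C(=N)N)c(F)c3)s2)c1` — 1430 nM

These three compounds were tested in a functional assay on NCI-H23 cells (Homo sapiens) for inhibition, read by sulforhodamine B assay, with a stated time of 48 h; a higher number here means a weaker inhibitor of growth, a lower number a stronger inhibitor of growth. Compound 2 gives the lowest of the three numbers, but compound 3 and compound 1 both lie within the usual scatter of it, so the three cannot be told apart on these numbers alone. Compound 4 `N=C(N)c1ccc(-c2ccc(-c3ccccc3)s2)cc1F` has not yet been measured. It differs from compound 2 in one place: hydrogen in place of chloro on an aromatic carbon. Going by the values given here, no measured pair shows this change, so its effect here is unknown. A small weakening, possibly not beyond the scatter, is expected, a step of a 1.7-fold higher number from compound 2 to compound 4 (0.22 log units; within the scatter). For compound 4 the estimate in this assay is 1900 nM, with an expected range from 700 nM to 5500 nM.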

Compound 4, concentration for 50% growth inhibition: 11600 nM
Compound 4: middle estimate off by 6.1-fold (0.79 log units), on the low side; measured number above the stated range.
By their numbers in this assay, from the lowest: compounds 2, 3 and 1 (each within the scatter of the next); then compound 4.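

The chloro on this aromatic carbon, para to a large group, clearly counts: going from 4-chlorophenyl to phenyl gives a 10-fold higher number from compound 2 to compound 4 (1.00 log units; beyond the scatter), a step beyond the scatter. The earlier compounds shown here all carry groups on that outer ring and form no pair differing in one place, and their numbers lie within the scatter of one another. Nothing measured here explains the size of this loss. Still open, from the compounds shown here alone, is whether a different group on this carbon, such as bromo, methyl or nitrile, would match chloro or fall closer to hydrogen.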